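Swapping the Carbonyl Group of Compound 3 for Methylsulfonyl

The source may report more compounds than this note shows. Statements on the series, on what has been measured and on what is new or still open speak of the compounds shown alone.

Of the compounds shown here, three on a shared core have been measured in a functional assay on MCF7 cells (Homo sapiens) for antiproliferative activity; a higher number here means a weaker inhibitor, a lower number a stronger inhibitor. Compound 1 (`O=C(Nc1ccc(O)c2c(=O)cc(-c3ccccc3Cl)oc12)c1ccccc1`) gives 7100 nM, compound 2 (`O=C(Nc1ccc(O)c2c(=O)cc(-c3ccccc3Cl)oc12)c1ccc(Cl)c(Cl)c1`) gives 15000 nM, and compound 3 (`COc1ccc(C(=O)Nc2ccc(O)c3c(=O)cc(-c4ccccc4Cl)oc23)cc1`) gives 3500 nM. Compound 3 therefore has the lowest number of the three and is the strongest inhibitor of the set.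

Compound 4 (`CS(=O)(=O)Nc1ccc(O)c2c(=O)cc(-c3ccccc3Cl)oc12`) has methylsulfonyl in place of (4-methoxyphenyl)carbonyl on a nitrogen on an aromatic ring.

The measured steps all concern the group on the carbonyl carbon. Methoxy in place of hydrogen on an aromatic carbon gives a 2.0-fold lower number from compound 1 to compound 3 (0.31 log units; beyond the scatter). The 3,4-dichlorophenyl in place of phenyl gives a 2.1-fold higher number from compound 1 to compound 2 (0.32 log units; beyond the scatter), and 4-methoxyphenyl in place of 3,4-dichlorophenyl gives a 4.3-fold lower number from compound 2 to compound 3 (0.63 log units; beyond the scatter). Going by the values given here, all three are modest, but none replaces the carbonyl group itself, so no measured step tests this change directly and the expectation is loose.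

Compound 3 at 3500 nM already sits at the low end of the series, whereas compound 2 reaches 15000 nM, so a modest move toward a higher number is the likelier outcome in this assay. The expected change is a 2.6-fold higher number from compound 3 to compound 4 (0.41 log units; beyond the scatter). Compound 4 is estimated at 9000 nM, with an expected range from 3000 nM to 30000 nM.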

Compound 4, half-maximal inhibitory concentration: 25000 nM
Beside the measured number, compound 4's estimate is 2.8-fold (0.44 log units) below it; the range from low to high includes it.
By their numbers in this assay, from the lowest: compound 3; then compound 1; then compounds 2 and 4 (each within the scatter of the next).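

In this assay, methylsulfonyl on the nitrogen on an aromatic ring gives a 7.1-fold higher number from compound 3 to compound 4 (0.85 log units; beyond the scatter). This is the largest step in the series and the first to replace the carbonyl itself rather than alter the aryl group it carries, showing that this position tolerates less than the changes on that aryl group alone had suggested. The size of the penalty depends on which group leaves: the change gives a 3.5-fold higher number from compound 1 to compound 4 (0.55 log units; beyond the scatter), while a 1.7-fold higher number from compound 2 to compound 4 (0.22 log units; within the scatter) lies within the scatter, so methylsulfonyl matches the (3,4-dichlorophenyl)carbonyl compound but loses ground to the benzoyl and (4-methoxyphenyl)carbonyl compounds. Nothing available explains these differences.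

The change removes the carbonyl and the aromatic ring together, so the compounds shown do not separate the contribution of the ring from that of the linking group. A 4-methoxyphenylsulfonyl group on the same nitrogen would keep the ring while changing the link, and an acetyl group would keep the carbonyl while losing the ring, so each would address one half of that question.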